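Exchanging the Group on an Ester Carbonyl

A few compounds are considered here, and "the series" means these few. Any claim that something is new, unique, unknown or untested is made for them only; others in the source may bear on it.

Going by the values given here, in a functional assay on HCT-116 cells (Homo sapiens) for cytotoxicity, read by sulforhodamine B assay, with a stated time of 72 h (on this read-out higher numbers stand for weaker inhibition and lower numbers for stronger inhibition), compound 1 (`C=C1C(=O)O[C@@H]2CC(C)=C([C@@H](C)CCCOC(C)=O)[C@@H](OC(=O)CCl)[C@H]12`) gives 18800 nM and compound 2 (`C=C1C(=O)O[C@@H]2CC(C)=C([C@@H](C)CCCOC(C)=O)[C@@H](OC(=O)COc3cccc4[nH]nnc34)[C@H]12`) gives 23700 nM so that compound 2 sits within the scatter of the only other number available. Compound 3 (`C=C1C(=O)O[C@@H]2CC(C)=C([C@@H](C)CCCOC(C)=O)[C@@H](OC(=O)c3cccc(F)c3)[C@H]12`) carries a group of 7 heavy atoms (6 carbon, 1 fluorine; one six-membered aromatic ring of carbon only) in place of a group of 11 heavy atoms (7 carbon, 3 nitrogen, 1 oxygen; one five-membered aromatic ring with 3 hetero atoms, one six-membered aromatic ring of carbon only), on a carbonyl carbon relative to compound 2. Among the compounds with values here, the one measured step bearing on this (a 1.3-fold higher number from compound 1 to compound 2 (0.10 log units; within the scatter)) also exchanged a group, on a saturated chain carbon bound to a carbonyl carbon, and stayed within the scatter. In this assay no step beyond the scatter is therefore expected, and the expected step is a 1.4-fold lower number from compound 2 to compound 3 (0.14 log units; within the scatter) for now. Compound 3 is estimated at 17000 nM with an expected range from 7000 nM to 40000 nM in this measurement.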

Compound 3, half-maximal inhibitory concentration: 14500 nM
The estimate for compound 3 lay 1.2-fold (0.07 log units) above the measured number; the measured number falls inside the stated range.
By their numbers in this assay, from the lowest: compounds 3, 1 and 2 (each within the scatter of the next).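

In this assay the two new steps, a 1.6-fold lower number from compound 2 to compound 3 (0.21 log units; within the scatter) and a 1.3-fold lower number from compound 1 to compound 3 (0.11 log units; within the scatter), both exchange the whole group on the carbonyl carbon, whereas the earlier step exchanged a group one carbon further out. Both stay within the scatter, so 3-fluorophenyl, chloromethyl and the larger group of compound 2 cannot be told apart at this position. No evidence is available that would explain this result. On these data alone, whether an amine, a carboxylic acid or a longer chain on this carbonyl carbon would move the number beyond the scatter stays open, as does the effect of phenyl without its fluorine.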